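Working notes: methoxy in place of bromo

The compounds below may be only part of what the source reports. "The series", "measured", "known", "first", "only" and "open" are said of these compounds alone.

Values in a functional assay (CEM-VLB cells, Homo sapiens) for antiproliferative activity, read by sulforhodamine B assay, with a stated time of 48 h (on this read-out higher numbers stand for weaker inhibition and lower numbers for stronger inhibition), so far:
- Compound 1 `O=C1NCCN1c1ccc(S(=O)(=O)Nc2ccc3[nH]ccc3c2)cc1` gives 4840 nM
- Compound 2 `O=C1NCCN1c1ccc(S(=O)(=O)Nc2cccc(Br)c2)cc1` gives 250 nM

Compound 2 holds the lower of the two numbers, and its gap to compound 1 lies beyond the scatter. Compound 3 `COc1cccc(NS(=O)(=O)c2ccc(N3CCNC3=O)cc2)c1` is still unmeasured. It carries methoxy in place of bromo on an aromatic carbon, meta to a large group: methoxy in place of bromo on an aromatic carbon. Within the data shown here, no measured pair isolates a change at this place, so the expectation rests on thin evidence. A modest weakening in this assay is expected, meaning a move to a higher number that may only just clear the scatter. The expected size is a 2.2-fold higher number from compound 2 to compound 3 (0.34 log units; beyond the scatter). For compound 3 the estimated value is 550 nM, with an expected range of 170 nM to 1800 nM.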

Compound 3, half-maximal inhibitory concentration: 700 nM
For compound 3 the middle estimate is 1.3-fold (0.10 log units) below the measured one; measured number inside the range.
By their numbers in this assay, from the lowest: compound 2; then compound 3; then compound 1.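

In this assay, among these compounds, the change from 3-bromophenyl to 3-methoxyphenyl gives a 2.8-fold higher number from compound 2 to compound 3 (0.45 log units; beyond the scatter), the first reading of a change at a single place. This place, on an aromatic carbon meta to a large group, therefore responds to the group it carries, though methoxy in place of bromo costs only a modest step that lies beyond the scatter. No measured evidence on hand accounts for this step.

Going by these compounds, a single step sets no trend, so it remains open how the number would move with an amine, a carboxylic acid or a longer chain such as ethoxy at this place. On these data alone, it also remains open whether methoxy in place of bromo would give a step of similar size elsewhere on the same ring.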